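Adding a Second Fluorine and Cytotoxicity in MT2 Cells

This account rests on a few compounds, and the source may have more. Where it says the series, first, only, none or still open, it means among the compounds named here.

Compound 1 `Cc1nc(C)c([C@H](OC(C)(C)C)C(=O)O)c(N2CCC(C)(C)CC2)c1-c1ccc2c(c1)CC[C@@H](Cc1ccc(F)cc1)O2`, compound 2 `Cc1nc(C)c([C@H](OC(C)(C)C)C(=O)O)c(N2CCC(C)(C)CC2)c1-c1ccc2c(c1)CC[C@H](Cc1ccc(F)cc1)O2` and compound 3 `Cc1nc(C)c([C@H](OC(C)(C)C)C(=O)O)c(N2CCC(C)(C)CC2)c1-c1ccc2c(c1)CCN(Cc1ccc(F)cc1)C2` share one core and differ from one another in a single part of the structure. In a toxicity assay on MT2 cells (Homo sapiens) for cytotoxicity (on this read-out lower numbers stand for higher toxicity in this test and higher numbers for lower toxicity in this test), compound 1 gives only a limit of the assay, >= 22000 nM. Compound 2 likewise gives only a limit, >= 22000 nM. Compound 3 also gives only a limit, >= 22000 nM. The step that the two limits leave unreadable from compound 1 to compound 2 cannot be read because of the limit of >= 22000 nM in this assay, at which 3 of the 3 values shown sit. Compound 4 `Cc1nc(C)c([C@H](OC(C)(C)C)C(=O)O)c(N2CCC(C)(C)CC2)c1-c1ccc2c(c1)CCN(Cc1ccc(F)cc1F)C2` differs from compound 3 by fluoro in place of hydrogen on an aromatic carbon. Among the compounds with values here, no measured step bears on this change with a readable size, and all three measured compounds sit at the same limit. For compound 4 the expected step is a step that the limit leaves unreadable from compound 3 to compound 4, none beyond the scatter. Compound 4 is therefore estimated at 30000 nM, within 12000 nM to 80000 nM, most likely reported again as a limit.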

Compound 4, half-maximal cytotoxic concentration: >= 24000 nM
Compound 4 ended at the assay's limit; the forecaster's own chance of this, stated with the estimate: 80%; the middle value is on the limit's open side.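

Compound 3 and compound 4 both give only limits in this assay, so no size can be read for the step between them. The compounds shown leave open whether the second fluorine changes cytotoxicity at all.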